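Ether-Bearing Carbamate Replaced by an Isopropylsulfanyl Carbonyl

The compounds below may be only part of what the source reports. "The series", "measured", "known", "first", "only" and "open" are said of these compounds alone.

Compound 1 `CCOC(=O)N1CCC(Oc2ncnc3c2CCN3c2ccc(S(C)(=O)=O)cc2F)CC1`: 251 nM
Compound 2 `COCCOC(=O)N1CCC(Oc2ncnc3c2CCN3c2ccc(S(C)(=O)=O)cc2F)CC1`: 316 nM

In a functional assay on CHO-K1 cells for agonist activity at Glucose-dependent insulinotropic receptor (Homo sapiens), read by a luciferase reporter, with a stated time of 5 h (on this read-out higher numbers stand for an effect only at larger amounts of compound and lower numbers for an effect already at smaller amounts), compound 2 gives 316 nM. Among the compounds with values here, its number is the larger of the two measured, yet the only step that reaches it, a 1.3-fold higher number from compound 1 to compound 2 (0.10 log units; within the scatter), is within the scatter, so the two compounds cannot be told apart on these data.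

Compound 3 `CC(C)SC(=O)N1CCC(Oc2ncnc3c2CCN3c2ccc(S(C)(=O)=O)cc2F)CC1` differs from compound 2 by isopropylsulfanyl in place of 2-methoxyethoxy on a carbonyl carbon. Within the data shown here, the single measured step, a 1.3-fold higher number from compound 1 to compound 2 (0.10 log units; within the scatter), altered only the tail of the carbamate and left the oxygen link to the carbonyl untouched; it bears on the present change only in showing that the shared core tolerated a change at this end without a shift beyond the scatter. Among the measured compounds shown here, no measured pair addresses the exchange of the oxygen link for sulfur. Compound 3 is therefore expected to show a step of a 1.1-fold lower number from compound 2 to compound 3 (0.02 log units; within the scatter), no larger than the scatter, giving an estimate of 300 nM with a range from 100 nM to 1000 nM.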

Compound 3, half-maximal effective concentration: 10 nM
The estimate for compound 3 lay 30-fold (1.48 log units) above the measured number, outside the stated range (below it).
By their numbers in this assay, from the lowest: compound 3; then compounds 1 and 2 (each within the scatter of the next).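

In this assay, the group on a carbonyl carbon whose other neighbour is an amide-type nitrogen in a ring can move the number far beyond the scatter: isopropylsulfanyl in place of 2-methoxyethoxy gives a 32-fold lower number from compound 2 to compound 3 (1.50 log units; beyond the scatter), and isopropylsulfanyl in place of ethoxy gives a 25-fold lower number from compound 1 to compound 3 (1.40 log units; beyond the scatter). The earlier step changed only the chain beyond the oxygen and stayed within the scatter, whereas these two steps, from either oxygen-linked group, are both large. Nothing on hand accounts for the size of these steps.

The compounds shown do not separate the sulfur link from the isopropyl group, as both enter together in compound 3. A comparison with isopropoxy or ethylsulfanyl on the same carbonyl carbon would show how much of the step belongs to each.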